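Restoring an Aryl Ring on the Sulfonamide

This account rests on a few compounds, and the source may have more. Where it says the series, first, only, none or still open, it means among the compounds named here.

The series shares a core carrying an amide-linked anilide; compound 1 `CCOc1ccc(C(=O)Nc2cccc(NC(=O)COc3ccc4c(=O)ccoc4c3)c2)cc1` bears an ethoxybenzamide on that aniline nitrogen, and compound 2 `Cn1ccc(S(=O)(=O)Nc2cccc(NC(=O)COc3ccc4c(=O)ccoc4c3)c2)n1` bears a methylpyrazole sulfonamide in its place. In an assay on isolated protein for inhibition of Rho-associated protein kinase 1 (Homo sapiens), read by scintillation counting, radiometric assay and 33P incorporation, with a stated time of 40 min, in the presence of a further agent that is not named here (a higher number here means a weaker inhibitor, a lower number a stronger inhibitor), compound 1 gives 17 nM. In this assay compound 2 reaches only a limit, > 10000 nM, so its position is known merely as a bound (the limit of > 10000 nM in this assay, at which 1 of the 2 values shown sits). Within the data shown here, the step of an at least 580-fold higher number from compound 1 to compound 2 (2.76 log units; beyond the scatter) is therefore the only measured guide, and it bundles two changes at once: the amide becoming a sulfonamide and the benzene ring becoming a pyrazole. Compound 3 `O=C(COc1ccc2c(=O)ccoc2c1)Nc1cccc(NS(=O)(=O)c2ccc(C(F)(F)F)cc2)c1` unpicks part of that bundle, with 4-(trifluoromethyl)phenyl in place of 1-methyl-1H-pyrazol-3-yl on a sulfonyl sulfur. Since the benzene ring returns while the sulfonamide stays, compound 3 is expected to recover some but probably not all of the loss seen in an at least 580-fold higher number from compound 1 to compound 2 (2.76 log units; beyond the scatter) from compound 1, giving an estimated step of an at least 3.3-fold lower number from compound 2 to compound 3 (0.52 log units; beyond the scatter). Compound 3 is accordingly expected to fall near 3000 nM, with a plausible range from 300 nM to 20000 nM, and a real chance that this assay again reports only a limit.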

Compound 3, half-maximal inhibitory concentration: > 10000 nM
Compound 3: a limit, no number (the forecaster's own chance of this, stated with the estimate: 35%); middle value at least 3.3-fold (0.52 log units) away from the limit.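

Compound 2 and compound 3 both stand only as limits in this assay, so the step between them cannot be read: the limit of > 10000 nM in this assay, at which 2 of the 3 values shown sit.

The compounds shown leave open how 4-(trifluoromethyl)phenyl and 1-methyl-1H-pyrazol-3-yl rank on the sulfonyl sulfur, and how much of the loss from compound 1 belongs to the sulfonamide alone.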